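The source may report more compounds than this note shows. Statements on the series, on what has been measured and on what is new or still open speak of the compounds shown alone.

Measured compounds:

compound 1, `CCCc1nc2ccccc2c(=O)n1/N=C/c1ccc(Oc2ccc(F)cc2)cc1`: 5.22
compound 2, `Cc1cc(Oc2ccc(/C=N/n3c(C)nc4ccccc4c3=O)cc2)ccc1Cl`: 4.41
compound 3, `Cc1nc2ccccc2c(=O)n1/N=C1/C(=O)Nc2ccccc21`: 2.23

Of the compounds shown here, three share the same core and have been measured in a physicochemical assay for lipophilicity, in phosphate buffer, measured as octanol-water partition; on this read-out higher numbers stand for higher lipophilicity and lower numbers for lower lipophilicity. Compound 1 gives 5.22, compound 2 gives 4.41, and compound 3 gives 2.23. Compound 3 stands lowest of the three; compound 2 lies well beyond the scatter above it, and compound 1 is further still. Within the data shown here, compounds 1 and 2 carry a bulky aryl ether arm where compound 3 carries a small ring-fused amide, and no pair among the three differs in one place only, so no single step has been measured.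

Among the measured compounds shown here, compound 4, `CCCc1nc2ccccc2c(=O)n1/N=C1/C(=O)Nc2ccccc21`, is the one compound not yet measured in this assay. It differs from compound 3 in one place: ethyl in place of hydrogen on a saturated chain carbon bound to an aromatic carbon. The same change, read one bond further out, is methyl to propyl.

For the measured compounds named here, there is no measured step of this kind within the set to lean on. Still, a change of this sort in this assay is expected to move the number upward by a moderate amount, clearly beyond the scatter, which is the step from a number 0.97 log units higher from compound 3 to compound 4 (beyond the scatter) that the estimate implies. Compound 4 is therefore expected to give about 3.2, most likely between 2.7 and 3.7.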

Compound 4, partition coefficient: 3.23
Compound 4: middle estimate off by 0.03 log units, on the low side, within the range that was stated.
By their numbers in this assay, from the lowest: compound 3; then compound 4; then compound 2; then compound 1.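

Among these compounds, until compound 4, no two compounds in this set differed in one place only, so the effect of a change at this position could not be read directly. In this assay, putting ethyl in place of hydrogen on a saturated chain carbon bound to an aromatic carbon, which can also be read as methyl to propyl, gives a number 1.00 log units higher from compound 3 to compound 4 (beyond the scatter) and shows that this read-out responds to a change at this position, by more than repeat measurements would scatter. Nothing measured here explains why the number moves by this amount.

Only methyl and propyl are shown at this position when compared directly, so it remains open whether a longer chain such as butyl or hexyl would keep raising the number, and what a branched chain such as isopropyl would do. Also open, from the compounds shown here alone, are how an amine or a carboxylic acid at this place would move the number, and whether methyl to propyl gives a similar step when the aryl ether arm of compound 1 and compound 2 replaces the ring-fused amide of compound 3 and compound 4.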